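Moving the Hydroxyl and Swapping One Ring on a Shared Core

The source may report more compounds than this note shows. Statements on the series, on what has been measured and on what is new or still open speak of the compounds shown alone.

Compound 1, `Oc1ccc(-c2cc(-c3ccccc3)cc(-c3ccccc3)n2)cc1`: 1300 nM
Compound 2, `Oc1ccc(-c2cc(-c3ccccc3)cc(-c3cccs3)n2)cc1`: 2400 nM
Compound 3, `Oc1cccc(-c2cc(-c3ccccc3)nc(-c3ccccc3)c2)c1`: 19500 nM

All three were tested in a functional assay on MDA-MB-231 cells (Homo sapiens) for cytotoxicity, read by ELISA, with a stated time of 2 days; a lower number here means a stronger inhibitor, a higher number a weaker inhibitor. Compound 1 and compound 2 share a core and differ in one place only: thiophen-2-yl in place of phenyl on an aromatic carbon. This change produced a 1.8-fold higher number from compound 1 to compound 2 (0.27 log units; within the scatter), so the two compounds cannot be told apart by this measurement.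

Compound 3 is built from the same atoms as compound 1, joined differently; the difference between the two cores is not broken down here. Compound 3 is the weakest of the three, its gap to compound 2 and to compound 1 lying beyond the scatter in both cases.

Compound 4, `Oc1cccc(-c2cc(-c3ccccc3)nc(-c3cccs3)c2)c1`, has not yet been measured. It stands to compound 3 as compound 2 stands to compound 1: thiophen-2-yl in place of phenyl on an aromatic carbon. The surroundings are not identical, since in compound 1 the site is meta to a 4-hydroxyphenyl group while in compound 3 it is meta to a 3-hydroxyphenyl group, so this is the same kind of change rather than the same change. The step from compound 3 to compound 4 is expected to be about a 1.7-fold higher number from compound 3 to compound 4 (0.23 log units; within the scatter), resting on the earlier step of a 1.8-fold higher number from compound 1 to compound 2 (0.27 log units; within the scatter). Compound 4 is therefore estimated to give about 33000 nM in this assay. For compound 4 the expected range runs from 14000 nM to 80000 nM.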

Compound 4, half-maximal inhibitory concentration: 17700 nM
Beside the measured number, compound 4's estimate is 1.9-fold (0.27 log units) above it; low and high end bracket the measured number.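

In this assay, putting thiophen-2-yl in place of phenyl on the core of compound 3 gave a 1.1-fold lower number from compound 3 to compound 4 (0.04 log units; within the scatter), so this pair cannot be told apart by this measurement, just as compound 1 and compound 2 could not. Set side by side, the two steps do not differ by more than repeated measurements would: the same change on two cores in this assay, a 1.8-fold higher number (0.27 log units; within the scatter) from compound 1 to compound 2 and a 1.1-fold lower number (0.04 log units; within the scatter) from compound 3 to compound 4, 2.0-fold (0.31 log units) apart, within the scatter of two such steps. The swap therefore carries across these two cores only in a limited sense: on neither core does the step lie beyond the scatter, which does not prove that the two rings are interchangeable, and two pairs in one assay say nothing about other cores or other assays.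

The compounds shown carry only phenyl or thiophen-2-yl at this site, so it remains open whether a different group there, such as an amine or a carboxylic acid, would give a step beyond the scatter on either core. Also open, on these data alone, is whether a methoxy group in place of the hydroxyl would give matching steps on the two cores.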